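Replacing the amine of compound 3 with chloro

The source may report more compounds than this note shows. Statements on the series, on what has been measured and on what is new or still open speak of the compounds shown alone.

Measured compounds:
compound 1, `CCN(CC)CC(=O)N1N=C(C)CC1c1ccccc1OC(C)=O`, 51200 nM
compound 2, `CC(=O)Oc1ccccc1C1CC(C)=NN1C(=O)CN(C(C)C)C(C)C`, 24500 nM
compound 3, `CC(=O)Oc1ccccc1C1CC(C)=NN1C(=O)CN1CCC(O)CC1`, 25600 nM

In a functional assay on PC-3 cells (Homo sapiens) for cytotoxicity, read by MTT assay, with a stated time of 48 h (on this read-out lower numbers stand for stronger inhibition and higher numbers for weaker inhibition), compound 3 gives 25600 nM, the second highest of the three numbers. Its nearest neighbour is compound 2, and the two lie within the scatter of each other, as a 1.0-fold higher number from compound 2 to compound 3 (0.02 log units; within the scatter) shows. Its furthest neighbour is compound 1, and here too the gap is within the scatter, as a 2.0-fold lower number from compound 1 to compound 3 (0.30 log units; within the scatter) shows. Among the measured compounds shown here, the only step beyond the scatter is a 2.1-fold lower number from compound 1 to compound 2 (0.32 log units; beyond the scatter), and it is modest.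

Compound 4, `CC(=O)Oc1ccccc1C1CC(C)=NN1C(=O)CCl`, differs from compound 3 by chloro in place of 4-hydroxypiperidin-1-yl on a saturated chain carbon bound to a carbonyl carbon. For the measured compounds named here, all three measured steps swap one amine for another on the same saturated chain carbon, and none of them removes the amine altogether, so no measured step bears directly on this change. The three amines moved the numbers only within a narrow band in this assay, which gives little reason to expect a large shift either way, but the change to chloro is of a different kind and the uncertainty is wide. Compound 4 is therefore expected to give about 18000 nM, between 4000 nM and 70000 nM, a step of a 1.4-fold lower number from compound 3 to compound 4 (0.15 log units; within the scatter) that is an estimate only.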

Compound 4, half-maximal inhibitory concentration: 3580 nM
Beside the measured number, compound 4's estimate is 5.0-fold (0.70 log units) above it; measured number outside the range, below it.
By their numbers in this assay, from the lowest: compound 4; then compounds 2, 3 and 1 (each within the scatter of the next, the first and the last beyond it).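

In this assay, going from an amine to chloro on a saturated chain carbon bound to a carbonyl carbon moves the number much further than the swaps of one amine for another did: a 7.2-fold lower number from compound 3 to compound 4 (0.85 log units; beyond the scatter), a 6.8-fold lower number from compound 2 to compound 4 (0.84 log units; beyond the scatter) and a 14-fold lower number from compound 1 to compound 4 (1.16 log units; beyond the scatter). This position is therefore not indifferent to what it carries: all three amines give higher numbers than chloro, none of them goes against this, and compound 4 is the only one of the four whose steps to all the others lie beyond the scatter. Nothing in the data explains why chloro stands apart from the amines.

The compounds shown leave open whether the lower number goes with chloro itself or simply with the absence of an amine, a question on which bromo, methoxy or a plain methyl in the same place would bear. They also leave open whether chloro would keep this number at the end of a longer chain, and whether a smaller amine such as dimethylamino would stay with the other amines or move towards compound 4.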